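Bromo to Chloro on Two Cores: Antiproliferative Read-out

A few compounds are considered here, and "the series" means these few. Any claim that something is new, unique, unknown or untested is made for them only; others in the source may bear on it.

Compound 1, `COc1cc(Cl)cc(/C=C/C(=O)c2ccc(Br)cc2)c1O`: 26.3%
Compound 2, `COc1cc(Br)cc(/C=C/C(=O)c2ccc(Br)cc2)c1O`: 48.3%
Compound 3, `COC(=O)C1=C(N)Oc2ccc(Br)cc2C1CC(=O)c1ccccc1`: 41.3%

All three numbers come from a functional assay on MCF7 cells (Homo sapiens) for antiproliferative activity, read by sulforhodamine B assay, with a stated time of 72 h, tested at 30 uM; on this read-out lower numbers stand for a stronger effect and higher numbers for a weaker effect at the one concentration tested. Compound 2 and compound 1 differ only by chloro in place of bromo on an aromatic carbon, and that change gave a number 22 percentage points lower from compound 2 to compound 1 (beyond the scatter). Compound 3 is built on another core, and the difference between the two cores is not broken down here. The value of compound 3 lies within the scatter of that of compound 2, while compound 1 sits beyond the scatter on the stronger side of compound 3.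

Compound 4, `COC(=O)C1=C(N)Oc2ccc(Cl)cc2C1CC(=O)c1ccccc1`, has not been measured. It differs from compound 3 by chloro in place of bromo on an aromatic carbon. This is the same kind of change as from compound 2 to compound 1, but not the same: there the ring was meta to a large group, meta to a methoxy group and para to a hydroxy group, whereas here it is part of a fused or bridged system of two rings, meta to a fused ring and para to a fused ring. Because a number 22 percentage points lower from compound 2 to compound 1 (beyond the scatter) was a modest drop, a step of the same direction is expected for compound 4, with a number 13.3 percentage points lower from compound 3 to compound 4 (beyond the scatter) in this assay. For the measured compounds named here, the single earlier example on a different core makes this expectation uncertain. Compound 4 is estimated at 28%, between 14% and 45%.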

Compound 4, a percentage reported as activity, at one concentration (the size of the read-out at that concentration, not a potency): 44.2%
Beside the measured number, compound 4's estimate is 16.2 percentage points below it; the measured number falls inside the stated range.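

In this assay, chloro in place of bromo on an aromatic carbon of the fused system of two rings gave a number 2.9 percentage points higher from compound 3 to compound 4 (within the scatter). Set beside the earlier case, the same change did not carry over from one core to the other: the same change on two cores in this assay, a number 22 percentage points lower (beyond the scatter) from compound 2 to compound 1 and a number 2.9 percentage points higher (within the scatter) from compound 3 to compound 4, 24.9 percentage points apart, beyond the scatter of two such steps. For the compounds shown here, this shows that, in this series, a step seen on one core cannot simply be added to a compound on another core, but with only two pairs it does not show what in the cores sets the steps apart or how the change would behave on a third core.

The compounds shown carry only bromo or chloro at this place, so they leave open what a fluoro group or an amine there would do on either core. They also leave open how the read-out would respond if the methyl ester of compound 3 gave way to a carboxylic acid or an amide.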